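The source may report more compounds than this note shows. Statements on the series, on what has been measured and on what is new or still open speak of the compounds shown alone.

For the measured compounds named here, compound 2 `O=C(O)c1cccc(C2CC2c2ccc(OCc3c(-c4c(Cl)cccc4Cl)noc3C3CC3)cc2Cl)c1` is one of two compounds measured in a physicochemical assay for solubility; a higher number here means a more soluble compound, a lower number a less soluble compound. In this assay compound 2 gives 20000 nM, the lowest of the two numbers. Its nearest neighbour is compound 1 `O=C(O)c1cncc(C2CC2c2ccc(OCc3c(-c4c(Cl)cccc4Cl)noc3C3CC3)cc2Cl)c1`, which in this assay gives 165000 nM; the step of an 8.3-fold lower number from compound 1 to compound 2 (0.92 log units; beyond the scatter) accompanied 3-carboxyphenyl in place of 5-carboxypyridin-3-yl on a saturated ring carbon. Compound 3 `O=C(O)c1ccc(C2CC2c2ccc(OCc3c(-c4c(Cl)cccc4Cl)noc3C3CC3)cc2Cl)cc1` has not yet been measured in this assay. It differs from compound 2 by 4-carboxyphenyl in place of 3-carboxyphenyl on a saturated ring carbon. Going by the values given here, no measured step covers such a move of the acid group around the ring; the one step available, from compound 1 to compound 2, swaps a ring nitrogen for a ring carbon and so offers little guidance. For compound 3 the expected step of no change at the digits printed from compound 2 to compound 3 (within the scatter) is therefore none beyond the scatter. Compound 3 is estimated at 20000 nM, with a range from 7000 nM to 60000 nM.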

Compound 3, solubility: 72000 nM
Compound 3: the middle estimate sits 3.6-fold (0.56 log units) below what was measured; the whole stated range lies below it.
By their numbers in this assay, from the lowest: compound 2; then compound 3; then compound 1.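

Moving the acid group around the ring, with the same atoms in a new arrangement, goes with a 3.6-fold higher number from compound 2 to compound 3 (0.56 log units; beyond the scatter) in this assay, so where the acid sits on this ring matters at this place, not only whether the ring holds a nitrogen. Compound 3 does not reach the level of the pyridine, as a 2.3-fold lower number from compound 1 to compound 3 (0.36 log units; beyond the scatter) shows, which leaves 5-carboxypyridin-3-yl with the highest number of the three, 4-carboxyphenyl in the middle and 3-carboxyphenyl lowest. Nothing measured here explains this order.

Open, on these data alone, is whether a ring nitrogen added to the 4-carboxyphenyl group would raise the number as it does against 3-carboxyphenyl. Also open, as far as these compounds go, is how a tetrazole or a primary amide in place of the carboxylic acid would read in this assay.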